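Ring Expansion on the Core Nitrogen: Compound 1 to Compound 4

A few compounds are considered here, and "the series" means these few. Any claim that something is new, unique, unknown or untested is made for them only; others in the source may bear on it.

Measured compounds:
- compound 1, `CN1CCN(c2ccc(Nc3ncc4nc(Nc5ccc(F)cc5)n([C@H]5CCN(C(=O)CO)C5)c4n3)cc2)CC1`: "not determined" (no result reported)
- compound 2, `CC(=O)N1CC[C@H](n2c(Nc3ccccc3)nc3cnc(Nc4ccc(N5CCN(C)CC5)cc4)nc32)C1`: "not determined" (no result reported)
- compound 3, `CN1CCN(c2ccc(Nc3ncc4nc(Nc5ccccc5)n([C@@H]5CCN(S(=O)(=O)C6CC6)C5)c4n3)cc2)CC1`: 200 nM

These three compounds share one core and differ in the groups attached around it. In a functional assay on NCI-H1975 cells (Homo sapiens) for antiproliferative activity, read by MTT assay, with a stated time of 72 h (a lower number here means a stronger inhibitor, a higher number a weaker inhibitor), compound 1 gives "not determined" (no result reported), so no number stands for it, and compound 2 likewise gives "not determined" (no result reported) in this assay. Only compound 3 has a number: in this assay compound 3 gives 200 nM. Compound 1 therefore has no measured position among these compounds; the single number available belongs to a compound with a different substituent set.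

Compound 4, `CN1CCN(c2ccc(Nc3ncc4nc(Nc5ccc(F)cc5)n([C@H]5CCCN(C(=O)CO)C5)c4n3)cc2)CC1`, is the subject of the next step. The change from compound 1 is 1-((hydroxymethyl)carbonyl)piperidin-3-yl in place of 1-((hydroxymethyl)carbonyl)pyrrolidin-3-yl on an aromatic nitrogen. For the measured compounds named here, no measured pair shows what such a change does here, so the expected size of the step in this assay cannot be drawn from the data; it is expected to stay within the usual scatter, with no clear direction, and the estimate rests on compound 3 as the only anchor. Compound 4 is expected to give about 250 nM in this assay, estimated between 40 nM and 1500 nM.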

Compound 4, half-maximal inhibitory concentration: 750 nM
Compound 4: the middle estimate sits 3.0-fold (0.48 log units) below what was measured, within the range that was stated.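

No step can be read between compound 1 and compound 4: compound 1 has no number to compare in this assay. What the change from 1-((hydroxymethyl)carbonyl)pyrrolidin-3-yl to 1-((hydroxymethyl)carbonyl)piperidin-3-yl does to activity stays open, and nothing shown accounts for the result of compound 4.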